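The source may hold more compounds than are shown below. What is called first, only, known or untested is meant among the compounds shown, and "the series" means these compounds.

In a functional assay on HeLa cells (Homo sapiens) for antiproliferative activity, read by sulforhodamine B assay (a higher number here means a weaker inhibitor of growth, a lower number a stronger inhibitor of growth), compound 1 `CC[C@H]1O[C@H](COCc2ccccc2)[C@@H](OCc2ccccc2)[C@H](OCc2ccccc2)[C@H]1O` gives only a limit, > 50000 nM. Compound 3 `CCC[C@H]1O[C@H](COCc2ccccc2)[C@@H](OCc2ccccc2)[C@H](OCc2ccccc2)[C@H]1O` gives 17400 nM in this assay. The step of an at least 2.8-fold lower number from compound 1 to compound 3 (0.45 log units; beyond the scatter) is methyl in place of hydrogen on a saturated chain carbon, two bonds along the chain from a saturated ring carbon; its size rests on the limit of > 50000 nM in this assay, at which 1 of the 3 values shown sits, and is therefore known only as a lower bound. Compound 2 `CCC[C@@H]1O[C@H](COCc2ccccc2)[C@@H](OCc2ccccc2)[C@H](OCc2ccccc2)[C@H]1O` gives 18900 nM in this assay, and the step of a 1.1-fold lower number from compound 2 to compound 3 (0.04 log units; within the scatter) shows that the configuration at that carbon makes no visible difference, a reading that follows from the fact that compounds 2 and 3 differ only in the configuration as drawn. The difference between the cores of compound 2 and compound 1 is not broken down here.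

Compound 4 `CCCC[C@@H]1O[C@H](COCc2ccccc2)[C@@H](OCc2ccccc2)[C@H](OCc2ccccc2)[C@H]1O` has not yet been measured. Its relation to compound 2 is methyl in place of hydrogen on a saturated chain carbon, three bonds along the chain from a saturated ring carbon, which is the same kind of change as that from compound 1 to compound 3, set one bond further along the chain, three bonds rather than two from the saturated ring carbon. Since the earlier step could only be bounded, a smaller gain is expected from compound 2 to compound 4, a 2.0-fold lower number from compound 2 to compound 4 (0.30 log units; within the scatter). Compound 4 is thus estimated at 9500 nM in this assay, between 4000 nM and 22000 nM.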

Compound 4, concentration for 50% growth inhibition: > 50000 nM
Compound 4 was reported as a limit; the forecaster's own chance of this, stated with the estimate: 5%; middle value at least 5.2-fold (0.72 log units) from the limit.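

Adding the methyl at this place gives an at least 2.6-fold higher number from compound 2 to compound 4 (0.42 log units; beyond the scatter), so in this assay the change does not keep its direction from one core to the other: the same change on two cores in this assay, an at least 2.8-fold lower number (0.45 log units; beyond the scatter) from compound 1 to compound 3 and an at least 2.6-fold higher number (0.42 log units; beyond the scatter) from compound 2 to compound 4, at least 7.6-fold (0.88 log units) apart, beyond the scatter of two such steps. Neither step has an exact size, since compound 1 and compound 4 each give only a limit: the limit of > 50000 nM in this assay, at which 2 of the 4 values shown sit. The comparison also does not separate the core from the place of the change, as propyl to butyl lies three bonds along the chain from the saturated ring carbon and ethyl to propyl lies two, so it shows that the change cannot be carried over unchanged in this series but not which of these differences is responsible.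

From the compounds shown here alone, whether a butyl chain on the core of compound 3 would behave like compound 4 remains open. So does the question of how an ethyl chain on the core of compound 2, a longer chain, or an amine at the end of the chain would fare in this assay.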